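Oral bioavailability of ester prodrugs on a shared bicyclic core

The compounds below may be only part of what the source reports. "The series", "measured", "known", "first", "only" and "open" are said of these compounds alone.

Measured so far:
compound 1, `CCCCCCCOC(=O)C(C)(C)COS(=O)(=O)ON1C(=O)N2C[C@H]1CC[C@H]2C(N)=O`: 66%
compound 2, `Cc1ccccc1OC(=O)OCCC(C)(C)COS(=O)(=O)ON1C(=O)N2C[C@H]1CC[C@H]2C(N)=O`: 34%

In an ADME assay on the whole organism (strain Beagle) for pharmacokinetics, with Canis familiaris (Canis lupus familiaris) as the target, read by LC-MS, with a stated time of 24 h, at a dose of 20 mg/kg by the oral route (on this read-out lower numbers stand for lower oral bioavailability and higher numbers for higher oral bioavailability), compound 1 gives 66%, the higher of the two numbers in hand. Compound 2 in this assay gives 34%, a gap to compound 1 that is beyond the usual scatter; the two structures differ in more than one place, so nothing is drawn from that pair beyond the two values themselves.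

Compound 3, `COCCOC(=O)C(C)(C)COS(=O)(=O)ON1C(=O)N2C[C@H]1CC[C@H]2C(N)=O`, is not yet measured. It is derived from compound 1 by a single change: methoxy in place of pentyl on a saturated chain carbon, two bonds along the chain from an oxygen next to a carbonyl group. The shared core and the sulfate-linked ester arm are kept; only the outer part of the ester group is shortened and given an oxygen.

Among the compounds with values here, no measured pair tracks this change, so the expectation rests on compound 1 alone. A step downward from compound 1, somewhat beyond the scatter, is expected: a number 16 percentage points lower from compound 1 to compound 3 (beyond the scatter). The estimate for compound 3 in this assay is 50%, with a range from 25% to 75%.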

Compound 3, oral bioavailability: 95%
Compound 3: the middle estimate sits 45 percentage points below what was measured; measured number above the stated range.
By their numbers in this assay, from the lowest: compound 2; then compound 1; then compound 3.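

In this assay, methoxy in place of pentyl on a saturated chain carbon, two bonds along the chain from an oxygen next to a carbonyl group, gives a number 29 percentage points higher from compound 1 to compound 3 (beyond the scatter). Within the data shown here, this is the first measured change at this position, and it shows that the heptyl ester of compound 1 can be cut back to the 2-methoxyethyl ester of compound 3 without a loss in this read-out; the number rises instead. No measurement in hand accounts for the rise, so the step stands as an observation about this one pair.

Since the exchange shortens the chain and brings in an oxygen at the same time, the two changes cannot be separated here; a plain ethyl or propyl ester at this place, without the oxygen, would set them apart. Also open, from the compounds shown here alone, is how far the trend runs along the chain, for instance whether a 2-ethoxyethyl ester or a 2-aminoethyl ester keeps the number of compound 3 or loses it.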